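The source may report more compounds than this note shows. Statements on the series, on what has been measured and on what is new or still open speak of the compounds shown alone.

In a functional assay on BGC-823 cells (Homo sapiens) for cytotoxicity, read by MTT assay, with a stated time of 72 h (a higher number here means a weaker inhibitor, a lower number a stronger inhibitor), compound 1 `CN1[C@@H]2c3[nH]c4ccccc4c3C[C@H]1[C@H](C#N)N1[C@@H](CNC(=O)c3ccc(Cl)cc3)c3[nH]c4ccccc4c3C[C@@H]21` gives 110 nM, the lowest of the two numbers measured. Compound 2 `CN1[C@@H]2c3[nH]c4ccccc4c3C[C@H]1[C@H](C#N)N1[C@@H](CNC(=O)c3cccc4c3CCCC4)c3[nH]c4ccccc4c3C[C@@H]21`, which carries a different group on the carbonyl carbon, gives 3540 nM in this assay, and the step of a 32-fold higher number from compound 1 to compound 2 (1.51 log units; beyond the scatter) shows how much was lost when the 4-chlorophenyl was exchanged there. Compound 3 `CN1[C@@H]2c3[nH]c4ccccc4c3C[C@H]1[C@H](C#N)N1[C@@H](CNC(=O)/C=C/c3cccc(C(F)(F)F)c3)c3[nH]c4ccccc4c3C[C@@H]21` has not yet been measured. It differs from compound 1 in that same place: 2-(3-(trifluoromethyl)phenyl)ethenyl in place of 4-chlorophenyl on a carbonyl carbon. Among the compounds with values here, the entering group brings more heavy atoms than the one it replaces, and the only measured step that bears on such an exchange, a 32-fold higher number from compound 1 to compound 2 (1.51 log units; beyond the scatter), points toward a weaker inhibitor; the entering group is not the one in compound 2, so the size is uncertain. The step expected here is a 7.3-fold higher number from compound 1 to compound 3 (0.86 log units; beyond the scatter). The estimate for compound 3 in this assay is 800 nM, with a range from 150 nM to 4000 nM.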

Compound 3, half-maximal inhibitory concentration: 910 nM
Compound 3: the middle estimate sits 1.1-fold (0.06 log units) below what was measured; low and high end bracket the measured number.
By their numbers in this assay, from the lowest: compound 1; then compound 3; then compound 2.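

Exchanging 4-chlorophenyl for 2-(3-(trifluoromethyl)phenyl)ethenyl on the carbonyl carbon also weakens the compound in this assay with an 8.3-fold higher number from compound 1 to compound 3 (0.92 log units; beyond the scatter) as the cost, so both exchanges shown at this place lose activity. The two entering groups are not equivalent, as a 3.9-fold lower number from compound 2 to compound 3 (0.59 log units; beyond the scatter) separates them, and the loss therefore depends on which group enters and not only on 4-chlorophenyl leaving. No separate measurement is available to explain these differences.

From the compounds shown here alone, the double bond and the trifluoromethyl group arrive together in compound 3, so their separate contributions remain open. A 3-(trifluoromethyl)phenyl group attached directly to the carbonyl carbon, or a plain 2-phenylethenyl group, would help to separate them, while a group carrying an amine would test a different kind of substituent at this place.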